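Removing the Methoxy Group from Compound 3

The compounds below may be only part of what the source reports. "The series", "measured", "known", "first", "only" and "open" are said of these compounds alone.

Of the compounds shown here, three have been measured in a functional assay on A-375 cells (Homo sapiens) for antiproliferative activity, read by MTT assay, with a stated time of 24 h, tested at 33.33 ug/mL; on this read-out lower numbers stand for a weaker effect and higher numbers for a stronger effect at the one concentration tested. Compound 1 `COc1ccc2nc(C(=O)Nc3ccc(-c4ccccc4)cc3)c(C)c(O)c2c1` gives 46.3%. Compound 2 `Cc1c(C(=O)Nc2ccc(-c3ccccc3)cc2)nc2ccccc2c1O` gives 34.3%. Compound 3 `COc1ccc2nc(C(=O)Nc3ccc(-c4ccccc4)cc3)c(C)c(C(=O)O)c2c1` gives 58.3%, the highest of the three numbers: it stands beyond the scatter above compound 1, the nearest, and further still above compound 2. Two single changes link these values. The step of a number 12 percentage points lower from compound 1 to compound 2 (beyond the scatter) followed hydrogen in place of methoxy on an aromatic carbon, and the step of a number 12 percentage points higher from compound 1 to compound 3 (beyond the scatter) followed carboxy in place of hydroxy on an aromatic carbon.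

Compound 4 `Cc1c(C(=O)Nc2ccc(-c3ccccc3)cc2)nc2ccccc2c1C(=O)O` has not yet been measured. It differs from compound 3 as follows: hydrogen in place of methoxy on an aromatic carbon. The measured step that bears on this change is a number 12 percentage points lower from compound 1 to compound 2 (beyond the scatter), a modest loss for the same replacement in the pair that carries hydroxy rather than carboxy. Carrying that step over, the expected change is a number 12.3 percentage points lower from compound 3 to compound 4 (beyond the scatter), a modest drop beyond the scatter. Compound 4 is therefore expected to give about 46%, with a likely range from 34% to 58%.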

Compound 4, a percentage reported as inhibition, at one concentration (the size of the read-out at that concentration, not a potency): 25.6%
For compound 4 the middle estimate is 20.4 percentage points above the measured one, and the stated range ends above it.
By their numbers in this assay, from the lowest: compounds 4 and 2 (each within the scatter of the next); then compound 1; then compound 3.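

The methoxy group does not contribute a fixed amount at this position. In this assay, hydrogen in place of methoxy on an aromatic carbon gives a number 32.7 percentage points lower from compound 3 to compound 4 (beyond the scatter), and the size of this step depends on the group carried elsewhere on the core: the same change on two cores in this assay, a number 12 percentage points lower (beyond the scatter) from compound 1 to compound 2 and a number 32.7 percentage points lower (beyond the scatter) from compound 3 to compound 4, 20.7 percentage points apart, beyond the scatter of two such steps. Carboxy in place of hydroxy on an aromatic carbon depends on the methoxy group in turn, for without it the step is a number 8.7 percentage points lower from compound 2 to compound 4 (within the scatter), and the gain seen with methoxy present does not appear: the same change on two cores in this assay, a number 12 percentage points higher (beyond the scatter) from compound 1 to compound 3 and a number 8.7 percentage points lower (within the scatter) from compound 2 to compound 4, 20.7 percentage points apart, beyond the scatter of two such steps. Among these four compounds, the two changes therefore do not add, and only compound 3, which carries both methoxy and carboxy, stands clear of all the others.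

The compounds shown leave open whether an ethoxy group, a chlorine atom or an amine at this place would pair with carboxy as methoxy does. They also leave open whether a carboxylic ester in place of the carboxy group would keep this dependence on methoxy.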